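The source may hold more compounds than are shown below. What is called first, only, known or untested is meant among the compounds shown, and "the series" means these compounds.

Working notes on the series. In a functional assay on SW480 cells (Homo sapiens) for antiproliferative activity, read by sulforhodamine B assay, with a stated time of 48 h (on this read-out higher numbers stand for weaker inhibition and lower numbers for stronger inhibition), compound 1 (`COc1cccc(/C=C/C(=O)/C=C(O)/C=C/c2cccc(OC)c2OC)c1OC`) gives 12100 nM as its value. Compound 2 (`COc1ccc(C=C(C(=O)/C=C/c2cccc(OC)c2OC)C(=O)/C=C/c2cccc(OC)c2OC)cc1OC`) gives 410 nM in the same read-out, the lower of the two numbers and so the stronger inhibition, and its gap to compound 1 lies beyond the scatter. These two compounds differ in more than one place, so no single-place step can be read from them.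

Among the measured compounds shown here, compound 3 (`COc1cc(OC)c(C=C(C(=O)/C=C/c2cccc(OC)c2OC)C(=O)/C=C/c2cccc(OC)c2OC)c(OC)c1`) has no measurement yet. It differs from compound 2 by 2,4,6-trimethoxyphenyl in place of 3,4-dimethoxyphenyl on a double-bonded chain carbon bound to a double-bonded chain carbon in a single place, with 2,4,6-trimethoxyphenyl in place of 3,4-dimethoxyphenyl on a double-bonded chain carbon bound to a double-bonded chain carbon. For the measured compounds named here, no measured pair shows a change at this place, so the expectation is anchored only on compound 2 at 410 nM and remains loose. The expected step of a 1.5-fold higher number from compound 2 to compound 3 (0.17 log units; within the scatter) in this assay is small, an estimated slight rise in the number that probably stays within the scatter. Compound 3 is expected at 600 nM within a range of 200 nM to 1800 nM on this estimate.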

Compound 3, half-maximal inhibitory concentration: 840 nM
The estimate for compound 3 lay 1.4-fold (0.15 log units) below the measured number; the measured number falls inside the stated range.
By their numbers in this assay, from the lowest: compound 2; then compound 3; then compound 1.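

In this assay, the series now has its first reading at this place, on a double-bonded chain carbon bound to a double-bonded chain carbon: 2,4,6-trimethoxyphenyl in place of 3,4-dimethoxyphenyl gives a 2.0-fold higher number from compound 2 to compound 3 (0.31 log units; beyond the scatter), a modest step that lies beyond the scatter. The number therefore responds to the aryl group here, though the entering group, which carries more heavy atoms and more hydrogen-bond acceptors than the leaving group, costs only a modest part of the inhibition seen with compound 2. Among the compounds shown here, the single step changes both the count and the arrangement of the methoxy groups, so it cannot assign the shift to either one, and nothing at hand gives a reason for it.

Still open, going by these compounds, is whether the arrangement or the number of methoxy groups drives the step, which a 3,4,5-trimethoxyphenyl group at the same place would help to separate. Also open, on these data alone, is how this place responds to groups of another kind, such as an amine or a carboxylic acid on the aromatic ring.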